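Replacing the fluorophenyl arm: stability of compound 3

The compounds below may be only part of what the source reports. "The series", "measured", "known", "first", "only" and "open" are said of these compounds alone.

Going by the values given here, compound 1 `CCCCc1nc(=O)c(S(=O)(=O)c2ccc(-c3ccc(F)cc3)cc2)c(O)n1-c1c(OC)cccc1OC` stands lowest of the two numbers measured so far: in an ADME assay on microsomes from liver (Rattus norvegicus) for metabolic stability, using NADPH, with a stated time of 10 min (a lower number here means that less of the compound is left, a higher number that more of the compound is left), compound 1 gives 5%. Among the compounds with values here, its nearest neighbour, compound 2 `CCCCc1nc(=O)c(S(=O)(=O)c2ccc(-n3ccccc3=O)cc2)c(O)n1-c1c(OC)cccc1OC`, gives 83% in this assay, and the step of a number 78 percentage points higher from compound 1 to compound 2 (beyond the scatter) is the only measured step. Compound 3 `CCCCc1nc(=O)c(S(=O)(=O)c2ccc(-n3cc(Cl)ccc3=O)cc2)c(O)n1-c1c(OC)cccc1OC` has not yet been measured in this assay. It differs from compound 1 by a group of 8 heavy atoms (5 carbon, 1 nitrogen, 1 oxygen, 1 chlorine; one six-membered aromatic ring with 1 hetero atom) in place of a group of 7 heavy atoms (6 carbon, 1 fluorine; one six-membered aromatic ring of carbon only), on an aromatic carbon. Within the data shown here, the entering group differs from the group that enters in compound 2 only by a chlorine, and that chlorine has no measured counterpart here; otherwise the change is the same exchange of the fluorophenyl for a six-membered aromatic ring with one hetero atom. The step from compound 1 to compound 2 therefore bears directly on this change, and it was large and beyond the scatter. An upward step of similar size is expected, allowing some margin for the chlorine, so the expected step is a number 67 percentage points higher from compound 1 to compound 3 (beyond the scatter). Compound 3 is estimated at 72% in this assay, with a range from 40% to 92%.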

Compound 3, percent of the compound remaining: 74%
Compound 3: the middle estimate sits 2 percentage points below what was measured, within the range that was stated.
By their numbers in this assay, from the lowest: compound 1; then compounds 3 and 2 (each within the scatter of the next).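

At this position, on an aromatic carbon para to a large group, a second entering ring with one hetero atom now replaces the 4-fluorophenyl, and this assay shows a number 69 percentage points higher from compound 1 to compound 3 (beyond the scatter) in this exchange, so the large rise seen with compound 2 is no longer a single case. Chloro in place of hydrogen on an aromatic carbon of the entering ring gives a number 9 percentage points lower from compound 2 to compound 3 (within the scatter) and leaves that rise in place, so the entering ring carries the chloro without a difference that can be told from the scatter. Nothing at hand accounts for either step.

The compounds shown leave open which part of the entering ring goes with the rise, since a plain phenyl, a pyridine without the carbonyl or a saturated ring such as piperidine in the same place would separate the ring atoms from the carbonyl and from the fluorine of the group that leaves. Also open, from the compounds shown here alone, is whether other groups on the entering ring, such as methyl, methoxy, nitrile or an amine, would read as the chloro does.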